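Cytotoxicity After Swapping a Thioether for a Cyclic Amine

A few compounds are considered here, and "the series" means these few. Any claim that something is new, unique, unknown or untested is made for them only; others in the source may bear on it.

Three measured compounds share one core and differ only in the group on an aromatic carbon. In an ADME assay on Akata cells (Homo sapiens) for cytotoxicity, with a stated time of 7 days (on this read-out higher numbers stand for lower toxicity in this test and lower numbers for higher toxicity in this test), compound 1 `CCCCCOc1nc(N)nc2c1ncn2/C=C1/CC1(CO)CO` gives > 20000 nM, which is a limit of the test rather than a number. Compound 2 `CCCSc1nc(N)nc2c1ncn2/C=C1/CC1(CO)CO` gives > 20000 nM in this assay, again a limit. Compound 3 `CCCCCCCCSc1nc(N)nc2c1ncn2/C=C1/CC1(CO)CO` gives > 20000 nM in this assay, also a limit. Because of the limit of > 20000 nM in this assay, at which 3 of the 3 values shown sit, the steps a step that the two limits leave unreadable from compound 1 to compound 2, a step that the two limits leave unreadable from compound 1 to compound 3 and a step that the two limits leave unreadable from compound 2 to compound 3 cannot be sized, so no change in toxicity from pentyloxy, propylsulfanyl or octylsulfanyl can be read.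

Compound 4 `Nc1nc(NC2CCCC2)c2ncn(/C=C3/CC3(CO)CO)c2n1` has not yet been measured in this assay. It differs from compound 3 by cyclopentylamino in place of octylsulfanyl on an aromatic carbon. Among the measured compounds shown here, no measured step gives a direction for this change, since every value so far sits at the same limit. Compound 4 is therefore expected to stay at that limit as well. The step that the limit leaves unreadable from compound 3 to compound 4 is estimated to be no more than scatter. Compound 4 is expected to give about 30000 nM in this assay, with a range from 15000 nM to 100000 nM.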

Compound 4, half-maximal cytotoxic concentration: > 20000 nM
Compound 4: no number, only a limit; the forecaster's own chance of this, stated with the estimate: 85%; the middle value lies beyond the limit too.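

Compound 4 also gives only a limit of the test, so the steps to it from compound 1, compound 2 and compound 3 cannot be read: the limit of > 20000 nM in this assay, at which 4 of the 4 values shown sit. The compounds shown leave open whether changing the group on this aromatic carbon alters toxicity at all in this assay.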